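The source may report more compounds than this note shows. Statements on the series, on what has been measured and on what is new or still open speak of the compounds shown alone.

Measured so far in an ADME assay on J774 cells (Mus musculus) for cytotoxicity, read by resazurin assay, with a stated time of 24 h; a higher number here means a weaker inhibitor, a lower number a stronger inhibitor:
- Compound 1 `Cc1ncc([N+](=O)[O-])n1CCCCBr`: 61 ug/mL
- Compound 2 `Cc1ncc([N+](=O)[O-])n1CCCN1CCCCC1`: > 100 ug/mL, a limit of the assay

Among the compounds with values here, compound 1 holds the only actual number in this assay, 61 ug/mL. Compound 2 sits at the limit of > 100 ug/mL in this assay, at which 1 of the 2 values shown sits.

Compound 3 `Cc1ncc([N+](=O)[O-])n1CCCN1CCCC1` has not yet been measured. It keeps the core of compound 1 but carries pyrrolidin-1-yl in place of bromomethyl on a saturated chain carbon, three bonds along the chain from an aromatic nitrogen.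

Within the data shown here, the only measured step that bears on this change puts piperidin-1-yl at the same place: an at least 1.6-fold higher number from compound 1 to compound 2 (0.21 log units; that floor lies within the scatter). A modest upward step in this assay is therefore expected, estimated as a 1.6-fold higher number from compound 1 to compound 3 (0.19 log units; within the scatter), and it is not expected to lie clearly beyond the scatter. For compound 3 the expected value is 95 ug/mL, with an estimated range from 50 ug/mL to 180 ug/mL.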

Compound 3, half-maximal inhibitory concentration: > 100 ug/mL
Compound 3 gave a limit, no number; the forecaster's own chance of this, stated with the estimate: 50%; at least 1.0-fold (0.02 log units) between middle value and limit.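

In this assay compound 3 also ends at a limit of the assay and gives no number (> 100 ug/mL). Pyrrolidin-1-yl in place of bromomethyl gives a step whose floor is still small (an at least 1.6-fold higher number from compound 1 to compound 3 (0.21 log units; that floor lies within the scatter)), so this result alone does not show a real change at this position. The step between compound 2 and compound 3 cannot be read, and what the new result adds is that a second ring-bearing group on this chain reaches the same ceiling: the limit of > 100 ug/mL in this assay, at which 2 of the 3 values shown sit.

The compounds shown leave open how far above the limit either ring group lies, so the two cannot be ranked. They also leave open whether an open-chain group such as diethylamino or a ring with a second hetero atom such as morpholin-4-yl would give a true number at this place.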